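Moving the Ethyl Group on the Benzyl Amide

This account rests on a few compounds, and the source may have more. Where it says the series, first, only, none or still open, it means among the compounds named here.

Compound 1 `O=C(O)c1ccc(CCOc2c(F)ccc3nc(C(=O)NCc4cccc(OCC5CC5)c4)[nH]c(=O)c23)cc1` in an ADME assay on HEK293 cells (Homo sapiens) for cytotoxicity, read by resazurin assay, with a stated time of 72 h (a lower number here means that less compound is tolerated, a higher number that more compound is tolerated), gives > 20000 nM, which is a limit of the assay.
Compound 2 `CCc1cccc(CNC(=O)c2nc3ccc(F)c(OCCc4ccc(C(=O)O)cc4)c3c(=O)[nH]2)c1` in this assay gives > 20000 nM, also a limit of the assay.

Compound 2 thus stands at the limit, and so does compound 1: the limit of > 20000 nM in this assay, at which 2 of the 2 values shown sit. Among the measured compounds shown here, the only measured step, a step that the two limits leave unreadable from compound 1 to compound 2, is therefore unreadable in size, and no measured step tells how much tolerance changes when a group is moved on the benzyl amide. Compound 3 `CCc1ccc(CNC(=O)c2nc3ccc(F)c(OCCc4ccc(C(=O)O)cc4)c3c(=O)[nH]2)cc1` differs from compound 2 only in 4-ethylphenyl in place of 3-ethylphenyl on a saturated chain carbon bound to an amide-type nitrogen. The two measured compounds sit at the limit, the change is small, and no readable step bears on it, so compound 3 is expected to remain at the limit as well. Compound 3 is estimated at about 30000 nM, between 15000 nM and 80000 nM, in this assay. This estimate means a step that the limit leaves unreadable from compound 2 to compound 3, expected to be none beyond the scatter.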

Compound 3, half-maximal cytotoxic concentration: > 20000 nM
Compound 3 gave a limit, no number; the forecaster's own chance of this, stated with the estimate: 85%; the middle value lies beyond the limit too.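

No step among compound 1, compound 2 and compound 3 can be read, since each result is a limit of the assay and not a number: the limit of > 20000 nM in this assay, at which 3 of the 3 values shown sit.

The compounds shown leave open how much of each compound is tolerated, and whether 4-ethylphenyl and 3-ethylphenyl differ at all.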